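Adding a trifluoromethyl group to compound 3

The source may report more compounds than this note shows. Statements on the series, on what has been measured and on what is new or still open speak of the compounds shown alone.

- compound 1 `Nc1ccccc1NC(=O)c1ccc(CNCc2nc(-c3ccc(C(F)(F)F)cc3)no2)cc1`: 2580 nM
- compound 2 `Nc1ccccc1NC(=O)c1ccc(CNCc2nc(-c3ccc(F)cc3)no2)cc1`: 1250 nM
- compound 3 `O=C(NO)c1ccc(CNCc2nc(-c3ccccc3)no2)cc1`: 7210 nM

In a functional assay on U-937 cells (Homo sapiens) for inhibition, read by MTT assay, with a stated time of 72 h (a higher number here means a weaker inhibitor, a lower number a stronger inhibitor), compound 3, at 7210 nM in this set, has the highest number of the three and is therefore the weakest inhibitor so far. Compound 4 `O=C(NO)c1ccc(CNCc2nc(-c3ccc(C(F)(F)F)cc3)no2)cc1` is compound 3 with a single change, (trifluoromethyl in place of hydrogen on an aromatic carbon), which in words is trifluoromethyl in place of hydrogen on an aromatic carbon, para to a large group.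

Going by the values given here, only one measured step bears on this change. The swap of fluoro in place of trifluoromethyl on an aromatic carbon gives a 2.1-fold lower number from compound 1 to compound 2 (0.31 log units; beyond the scatter) in this pair, a modest step. This evidence is indirect, since it compares trifluoromethyl with fluoro rather than with hydrogen, and both compounds in the pair also differ from compound 3 elsewhere in the structure. Among the compounds with values here, no measured pair compares hydrogen with trifluoromethyl directly. No clear direction can therefore be expected in this assay, and any step is expected to stay within the usual scatter. The expected outcome is a 1.2-fold lower number from compound 3 to compound 4 (0.08 log units; within the scatter) on this thin evidence. For compound 4 the estimate is 6000 nM, with an expected range of 2000 nM to 16000 nM in this assay.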

Compound 4, half-maximal inhibitory concentration: 8050 nM
The estimate for compound 4 lay 1.3-fold (0.13 log units) below the measured number; low and high end bracket the measured number.
By their numbers in this assay, from the lowest: compound 2; then compound 1; then compounds 3 and 4 (each within the scatter of the next).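

In this assay, going by these compounds alone, the first direct comparison of trifluoromethyl with hydrogen at this position gives a 1.1-fold higher number from compound 3 to compound 4 (0.05 log units; within the scatter), so the added group, with its 4 heavy atoms, produces no change that can be told from repeat-measurement scatter in this pair. The other end of the molecule gives a clearer result: with trifluoromethyl held constant, hydroxy in place of 2-aminophenyl on the amide-type nitrogen gives a 3.1-fold higher number from compound 1 to compound 4 (0.49 log units; beyond the scatter), a modest step beyond the scatter. Nothing measured here explains either result.

The compounds shown leave open whether this position stays as unresponsive with other groups, such as a methoxy group or an amine, since only hydrogen and trifluoromethyl can be compared directly on the hydroxy side. They also leave open whether the step between the hydroxy and 2-aminophenyl end groups keeps its size and direction when the trifluoromethyl is replaced by fluoro or hydrogen, as only the trifluoromethyl pair can be read.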